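The source may report more compounds than this note shows. Statements on the series, on what has been measured and on what is new or still open speak of the compounds shown alone.

Compound 1 `CCC#Cc1cn([C@H]2C[C@H](O)[C@@H](CO)O2)c(=O)[nH]c1=O` and compound 2 `CCCC#Cc1cn([C@H]2C[C@H](O)[C@@H](CO)O2)c(=O)[nH]c1=O` share the same core and differ only on the chain. In a functional assay on L1210 cells (Mus musculus) (a higher number here means a weaker inhibitor, a lower number a stronger inhibitor), compound 1 gives only a limit, > 1000 ug/mL. In this assay compound 2 likewise gives only a limit, > 1000 ug/mL. The step that the two limits leave unreadable from compound 1 to compound 2 is therefore unreadable, and compound 2 sits at the limit of > 1000 ug/mL in this assay, at which 2 of the 2 values shown sit. Compound 3 `COCC#Cc1cn([C@H]2C[C@H](O)[C@@H](CO)O2)c(=O)[nH]c1=O` differs from compound 2 by methoxy in place of ethyl on a saturated chain carbon bound to a triple-bonded carbon. Among the measured compounds shown here, no measured step bears on this change, since both values shown are limits, so no step beyond the scatter in this assay can be anticipated. Compound 3 is expected to give 2000 ug/mL, between 500 ug/mL and 8000 ug/mL. The step that the limit leaves unreadable from compound 2 to compound 3 is thus expected, most likely again reported only as a limit.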

Compound 3, concentration for 50% inhibition: 254 ug/mL
Estimate against measurement, compound 3: 7.9-fold (0.90 log units) above, outside the stated range (below it).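

In this assay, methoxy on a saturated chain carbon bound to a triple-bonded carbon brings a readable value, with an at least 3.9-fold lower number from compound 2 to compound 3 (0.59 log units; beyond the scatter) and with an at least 3.9-fold lower number from compound 1 to compound 3 (0.59 log units; beyond the scatter). On these data alone, both steps start from limits, so their full size stays open, and the step between compound 1 and compound 2 cannot be read. The ethyl and methyl chain ends give only a limit: the limit of > 1000 ug/mL in this assay, at which 2 of the 3 values shown sit.

As far as these compounds go, whether an amine or a hydroxy group on this chain carbon lowers the number further remains open. So does whether a longer ether chain, such as ethoxy, keeps the step.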